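Amino substituent variation on the shared core

The source may hold more compounds than are shown below. What is called first, only, known or untested is meant among the compounds shown, and "the series" means these compounds.

Measured so far:
compound 1 `CC(C(=O)NCc1ccc(C(F)(F)F)nc1NCC1CCN(C(=O)OC(C)(C)C)CC1)c1ccc(NS(C)(=O)=O)c(F)c1` — 1140 nM
compound 2 `CC(C(=O)NCc1ccc(C(F)(F)F)nc1NCc1ccc(Cl)cc1)c1ccc(NS(C)(=O)=O)c(F)c1` — 414 nM
compound 3 `C[C@H](C(=O)NCc1ccc(C(F)(F)F)nc1N1CCC[C@H]1CO)c1ccc(NS(C)(=O)=O)c(F)c1` — "not active" (no number reported)

In a functional assay on CHO-K1 cells for antagonist activity at transient receptor potential cation channel subfamily V member 1 (Homo sapiens), read by FLIPR (on this read-out lower numbers stand for stronger inhibition and higher numbers for weaker inhibition), compound 2 gives 414 nM, the lowest of the two numbers in hand. Compound 1 gives 1140 nM, a higher number that lies beyond the usual scatter, so compound 2 inhibits more strongly than compound 1. Among the measured compounds shown here, compound 3 is reported as "not active" (no number reported) without a number; no step between these pairs is worked out here, so only the bare values can be compared.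

Compound 4 `CC(C(=O)NCc1ccc(C(F)(F)F)nc1N1CCCCCCC1)c1ccc(NS(C)(=O)=O)c(F)c1` is not yet measured in this assay. It differs from compound 2 as follows: a group of 8 heavy atoms (7 carbon, 1 nitrogen; one eight-membered non-aromatic ring with 1 hetero atom) in place of a group of 9 heavy atoms (7 carbon, 1 nitrogen, 1 chlorine; one six-membered aromatic ring of carbon only), on an aromatic carbon

The eight-membered non-aromatic ring with 1 hetero atom sits directly on the aromatic carbon, and with it the hydrogen-bond donor of the (4-chlorobenzyl)amino group is gone. Compound 3 also carries a ring nitrogen directly on the core and returned "not active" (no number reported), which weighs toward a weaker result. A step of a 3.6-fold higher number from compound 2 to compound 4 (0.56 log units; beyond the scatter) toward a higher number is expected, beyond the scatter. For compound 4 an estimated 1500 nM is expected, within a range of 400 nM to 6000 nM.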

Compound 4, half-maximal inhibitory concentration: 27.8 nM
The estimate for compound 4 lay 54-fold (1.73 log units) above the measured number; the whole stated range lies above it.
By their numbers in this assay, from the lowest: compound 4; then compound 2; then compound 1.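

In this assay the exchange of the (4-chlorobenzyl)amino group for the eight-membered non-aromatic ring gives a 15-fold lower number from compound 2 to compound 4 (1.17 log units; beyond the scatter), so a low number at this aromatic carbon, next to the ring nitrogen, requires neither the hydrogen-bond donor nor the six-membered aromatic ring. A ring nitrogen sitting directly on this carbon is not unfavourable in itself, yet compound 3 also carries one and is reported as "not active", so that attachment alone does not settle the outcome. No measurement at hand bears on the cause of this step.

Open, from the compounds shown here alone, is whether the lower number belongs to the eight-membered ring as such or would also appear with a piperidine, an unsubstituted pyrrolidine or an open-chain dibutylamino group. Also open, going by these compounds, is what number would be measured if only the hydrogen-bond donor were removed. A methyl group on the nitrogen of the (4-chlorobenzyl)amino group would test this.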